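The source may report more compounds than this note shows. Statements on the series, on what has been measured and on what is new or still open speak of the compounds shown alone.

Three analogues of one core have been measured. Compound 1 `CN1C(=O)C(C2CC2)N(C)c2nc(Nc3ccc(S(N)(=O)=O)cc3)ncc21` gives 136 nM in an assay on Sf9 cells for inhibition of serine/threonine-protein kinase 4 (Homo sapiens), read by luminescence and ADP-Glo, with a stated time of 1 h, in the presence of a further agent that is not named here; on this read-out lower numbers stand for stronger inhibition and higher numbers for weaker inhibition. Compound 2 `CC(C)CC1C(=O)N(C)c2cnc(Nc3ccc(S(N)(=O)=O)cc3)nc2N1C` gives 77 nM, and compound 3 `CN1C(=O)C(c2cccc(F)c2)N(C)c2nc(Nc3ccc(S(N)(=O)=O)cc3)ncc21` gives 134 nM. The three numbers lie close: a 1.8-fold lower number from compound 1 to compound 2 (0.25 log units; within the scatter), a 1.0-fold lower number from compound 1 to compound 3 (0.01 log units; within the scatter) and a 1.7-fold higher number from compound 2 to compound 3 (0.24 log units; within the scatter). Compound 3 sits among the others, separated from compound 1 and compound 2 by no more than the scatter. Compound 4 `CN1C(=O)C(c2cccc(C(F)(F)F)c2)N(C)c2nc(Nc3ccc(S(N)(=O)=O)cc3)ncc21` carries trifluoromethyl in place of fluoro on an aromatic carbon. Among the measured compounds shown here, no measured step touches this change; the steps from compound 1 and from compound 2 to compound 3, which exchange the whole group on the saturated ring carbon, stayed within the scatter. For compound 4 the expected step in this assay is accordingly a 1.0-fold higher number from compound 3 to compound 4 (0.02 log units; within the scatter), nothing beyond the scatter. Compound 4 is estimated at 140 nM, with a range from 60 nM to 330 nM.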

Compound 4, half-maximal inhibitory concentration: 2710 nM
Compound 4: the middle estimate sits 19-fold (1.29 log units) below what was measured; the measured number lies above the stated range.
By their numbers in this assay, from the lowest: compounds 2, 3 and 1 (each within the scatter of the next); then compound 4.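

In this assay the substituent on the aromatic carbon meta to a large group matters, with trifluoromethyl in place of fluoro giving a 20-fold higher number from compound 3 to compound 4 (1.31 log units; beyond the scatter) where the earlier exchanges on the saturated ring carbon stayed within the scatter. The 3-(trifluoromethyl)phenyl group also falls behind isobutyl, with a 35-fold higher number from compound 2 to compound 4 (1.55 log units; beyond the scatter) on that carbon, and behind cyclopropyl, with a 20-fold higher number from compound 1 to compound 4 (1.30 log units; beyond the scatter) on the same carbon. No measurement shown accounts for this loss. Still open, from the compounds shown here alone, is whether chloro or methoxy at this aromatic carbon would track fluoro or trifluoromethyl.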